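The compounds below may be only part of what the source reports. "The series", "measured", "known", "first", "only" and "open" are said of these compounds alone.

Compound 3 `CC1=CC[C@H](C(C)C)c2cc(C)c(OC(=O)c3cccc([N+](=O)[O-])c3)cc21` carries an ester of a 3-nitrophenyl group on the shared core. In a functional assay on K562 cells (Homo sapiens) for antiproliferative activity, read by sulforhodamine B assay, with a stated time of 48 h, tested at 50 uM (on this read-out lower numbers stand for less inhibition and higher numbers for more inhibition at the one concentration tested (going by the name of the read-out)), compound 3 gives 15.9%, the lowest of the two numbers measured. Within the data shown here, compound 1 `CC1=CC[C@H](C(C)C)c2cc(C)c(OC(=O)c3ccc([N+](=O)[O-])cc3)cc21`, which bears a 4-nitrophenyl in the same place, gives 89% in this assay, and the change a number 73.1 percentage points lower from compound 1 to compound 3 (beyond the scatter) is the only single-point step in the set. Compound 2 `CC1=CC[C@H](C(C)C)c2cc(C)c(OC(=O)c3cccc(Cl)c3)cc21`, with a 3-chlorophenyl ester, is reported in this assay as "not active" (no number reported). Compound 4 `COc1ccc(C(=O)Oc2cc3c(cc2C)[C@@H](C(C)C)CC=C3C)cc1` differs from compound 3 by one exchange: 4-methoxyphenyl in place of 3-nitrophenyl on a carbonyl carbon. Among the measured compounds shown here, no measured pair shows this exchange, so the step must be judged indirectly. The 3-chlorophenyl ester compound 2 and the 3-nitrophenyl ester compound 3 both give little or no inhibition, while the 4-nitrophenyl ester compound 1 inhibits strongly; a 4-methoxyphenyl shares the substitution pattern of compound 1 but not its nitro group, and nothing measured tells how much that matters. A moderate rise is therefore expected, a number 19.1 percentage points higher from compound 3 to compound 4 (beyond the scatter), with wide uncertainty. Compound 4 is estimated at 35%, between 5% and 75%.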

Compound 4, a percentage reported as inhibition, at one concentration (the size of the read-out at that concentration, not a potency): 46.5%
Compound 4: the middle estimate sits 11.5 percentage points below what was measured; low and high end bracket the measured number.
By their numbers in this assay, from the lowest: compound 3; then compound 4; then compound 1.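

Going from the 4-nitrophenyl ester to the 4-methoxyphenyl ester in this assay gives a number 42.5 percentage points lower from compound 1 to compound 4 (beyond the scatter), so with the substituent named at 4 in both, the choice of group still matters, and a nitro group is not required for some inhibition. Exchanging 3-nitrophenyl for 4-methoxyphenyl gives a number 30.6 percentage points higher from compound 3 to compound 4 (beyond the scatter), so an ester without any nitro group can inhibit more than the 3-nitrophenyl ester, although this step changes both the group and its place on the ring. No separate measurement bears on why either step occurs.

The compounds shown leave open how a 4-chlorophenyl ester, a 4-aminophenyl ester or a 4-carboxyphenyl ester would behave. They also leave open whether an unsubstituted phenyl ester would fall closer to compound 3 or to compound 1.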